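Aryl in place of ethyl on the ring nitrogen

The source may hold more compounds than are shown below. What is called first, only, known or untested is meant among the compounds shown, and "the series" means these compounds.

Measured compounds:
Compound 1, `COc1ccccc1N1C(=O)CSC1C(=O)NCCCCc1ccccc1`, gives 60% in a functional assay on MG-63 cells (Homo sapiens) for inhibition, read by CCK-8 assay, with a stated time of 72 h, tested at 1 uM; a higher number here means more inhibition at the concentration tested (going by the name of the read-out), a lower number less inhibition.
Compound 2, `CCN1C(=O)CSC1c1cccc(C(=O)NCCCCc2ccccc2)c1`, gives 0% in this assay.
Compound 3, `O=C(NCCCCc1ccccc1)c1cccc(C2OCC(=O)N2c2cccc(F)c2)c1`, gives 66% in this assay.

Compound 2 stands lowest of the three numbers in this assay. Its nearest neighbour is compound 1, whose value lies higher by a margin beyond the scatter; compound 3 lies further away still, also beyond the scatter. Both of the compounds with a number well above zero carry an aromatic ring on the amide-type nitrogen of their five-membered ring, while compound 2 carries an ethyl there.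

Compound 4, `COc1c(F)cccc1N1C(=O)CSC1c1cccc(C(=O)NCCCCc2ccccc2)c1`, has not yet been tested in this assay. The change from compound 2 is 3-fluoro-2-methoxyphenyl in place of ethyl on an amide-type nitrogen in a ring. It brings compound 4 closer to compound 1, which shares a methoxy-bearing aryl on that nitrogen, and to compound 3, which shares the fluorine-bearing aryl and the same meta-linked benzamide arm.

Since compound 1 gives 60% and compound 3 gives 66%, a rise from compound 2 beyond the scatter is expected, with a number 55 percentage points higher from compound 2 to compound 4 (beyond the scatter) as the estimated step. Compound 4 is therefore expected to give about 55%, in a range from 25% to 80%.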

Compound 4, a percentage reported as inhibition, at one concentration (the size of the read-out at that concentration, not a potency): 0%
Estimate against measurement, compound 4: 55 percentage points above; the measured number lies below the stated range.
By their numbers in this assay, from the lowest: compounds 2 and 4 (each within the scatter of the next); then compounds 1 and 3 (each within the scatter of the next).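

Within this assay, the only pair that differs in one place shows that 3-fluoro-2-methoxyphenyl in place of ethyl on the amide-type nitrogen in the ring gives no change at the digits printed from compound 2 to compound 4 (within the scatter). The earlier compounds shown here had left an aromatic ring on that nitrogen looking like the feature that went with a sizeable number, but compound 4 goes against that pattern, so on the core of compound 2 this aryl group alone is not enough to raise the number. Nothing measured here accounts for this result.

As far as these compounds go, compound 1 and compound 3 each differ from compound 4 in more than one place, so those steps cannot be read, and it remains open which of those differences separates their numbers from that of compound 4. Also open, from the compounds shown here alone, is whether a plain phenyl, a longer chain such as butyl, or a chain ending in an amine on this nitrogen would give a different number on the core of compound 2.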